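This account rests on a few compounds, and the source may have more. Where it says the series, first, only, none or still open, it means among the compounds named here.

Compound 1 (`COc1cccc(/C=C2\CCC/C(=C\c3ccccc3Br)C2=O)c1OC`) gives > 50000 nM in an ADME assay on NHDF cells (Homo sapiens) for cytotoxicity, read by MTT assay, with a stated time of 72 h (on this read-out lower numbers stand for stronger inhibition and higher numbers for weaker inhibition), which is a limit of the assay and not a number. Compound 2 (`COc1cccc(/C=C2\CCC/C(=C\c3cccc(Br)c3)C2=O)c1OC`) gives 23900 nM and compound 3 (`COc1cccc(/C=C2\CCC/C(=C\c3ccc(Br)cc3)C2=O)c1OC`) gives 21400 nM, so compound 3 sits level with compound 2: a 1.1-fold lower number from compound 2 to compound 3 (0.05 log units; within the scatter). The two steps out of the limit compound are an at least 2.0-fold lower number from compound 1 to compound 2 (0.32 log units; beyond the scatter) and an at least 2.3-fold lower number from compound 1 to compound 3 (0.36 log units; beyond the scatter).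

The next change leads to compound 4 (`COc1cccc(/C=C2\CCC/C(=C\c3cccc(OC)c3OC)C2=O)c1`), with 3-methoxyphenyl in place of 4-bromophenyl on a double-bonded chain carbon bound to a double-bonded ring carbon. Within the data shown here, no measured step involves a methoxyphenyl group at this place, so the bromophenyl steps are the only guide, and they are a weak one. Since a 1.1-fold lower number from compound 2 to compound 3 (0.05 log units; within the scatter), no step beyond the scatter is expected in this assay, and no direction is favoured. The expected step is a 1.1-fold higher number from compound 3 to compound 4 (0.03 log units; within the scatter). For compound 4 the estimate is 23000 nM, with an expected range of 10000 nM to 50000 nM.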

Compound 4, half-maximal inhibitory concentration: 16400 nM
Beside the measured number, compound 4's estimate is 1.4-fold (0.15 log units) above it, within the range that was stated.
By their numbers in this assay, from the lowest: compounds 4, 3 and 2 (each within the scatter of the next). At a limit, above all of these: compound 1.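

In this assay, 3-methoxyphenyl on a double-bonded chain carbon bound to a double-bonded ring carbon stays level with both bromophenyl compounds that give numbers (a 1.3-fold lower number from compound 3 to compound 4 (0.12 log units; within the scatter) and a 1.5-fold lower number from compound 2 to compound 4 (0.16 log units; within the scatter)). Bromo is thus not required at this place for a number of this size, since methoxy in place of bromo on an aromatic carbon gives no step beyond the scatter. Among these compounds, the only new step beyond the scatter is an at least 3.0-fold lower number from compound 1 to compound 4 (0.48 log units; beyond the scatter), and it starts from a limit and not a number: the limit of > 50000 nM in this assay, at which 1 of the 4 values shown sits.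

Still open, from the compounds shown here alone, is whether an amine or a carboxylic acid on this aromatic ring would give a step beyond the scatter from compounds 2, 3 and 4. Also open, going by these compounds, is whether any group at this place gives a clearly lower number in this assay.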